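A repeated ring swap and its expected cost in potency

The compounds below may be only part of what the source reports. "The series", "measured", "known", "first", "only" and "open" are said of these compounds alone.

Three compounds have been measured in an ADME assay on K562 cells (Homo sapiens) for antiproliferative activity; a higher number here means a weaker inhibitor, a lower number a stronger inhibitor:

compound 1, `COc1ccc2nccc(CC[C@H]3OC[C@H](NCc4ccc5c(c4)OCCO5)CO3)c2c1`, gives 7400 nM
compound 2, `COc1ccc2nccc(CC[C@H]3OC[C@H](NCc4ccc5c(n4)NC(=O)CO5)CO3)c2c1`, gives 24000 nM
compound 3, `COc1ccc2nccc(CC[C@H]3CC[C@H](NCc4ccc5c(c4)OCCO5)CC3)c2c1`, gives 4200 nM

Compound 1 and compound 2 share one core and differ only in the group attached to it. The change from compound 1 to compound 2 is a group of 11 heavy atoms (7 carbon, 2 nitrogen, 2 oxygen; one six-membered non-aromatic ring with 2 hetero atoms, one six-membered aromatic ring with 1 hetero atom) in place of a group of 10 heavy atoms (8 carbon, 2 oxygen; one six-membered non-aromatic ring with 2 hetero atoms, one six-membered aromatic ring of carbon only), on a saturated chain carbon bound to an amine nitrogen. That change made the step of a 3.2-fold higher number from compound 1 to compound 2 (0.51 log units; beyond the scatter), so the newer group weakened the inhibitor noticeably.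

Compound 3 is built on a different core, and the difference between the cores of compound 1 and compound 3 is not broken down here. The values of compound 1 and compound 3 lie within the usual scatter of each other, so the two cores cannot be told apart on these numbers alone.

Compound 4, `COc1ccc2nccc(CC[C@H]3CC[C@H](NCc4ccc5c(n4)NC(=O)CO5)CC3)c2c1`, has not yet been measured. It stands to compound 3 as compound 2 stands to compound 1: the change from compound 3 to compound 4 is a group of 11 heavy atoms (7 carbon, 2 nitrogen, 2 oxygen; one six-membered non-aromatic ring with 2 hetero atoms, one six-membered aromatic ring with 1 hetero atom) in place of a group of 10 heavy atoms (8 carbon, 2 oxygen; one six-membered non-aromatic ring with 2 hetero atoms, one six-membered aromatic ring of carbon only), on a saturated chain carbon bound to an amine nitrogen, the same change at the same place as before. Among the compounds with values here, only one earlier instance of this change exists, so the expectation rests on it alone: the step from compound 3 to compound 4 is estimated at a 3.1-fold higher number from compound 3 to compound 4 (0.49 log units; beyond the scatter), in line with the step from compound 1 to compound 2. On that basis compound 4 is expected to give about 13000 nM in this assay, most likely between 5000 nM and 35000 nM.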

Compound 4, half-maximal inhibitory concentration: 12000 nM
Compound 4: middle estimate off by 1.1-fold (0.03 log units), on the high side; measured number inside the range.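

In this assay, putting the new group in place of the 2,3-dihydro-1,4-benzodioxin-6-yl group weakened the inhibitor on this core as well, giving a 2.9-fold higher number from compound 3 to compound 4 (0.46 log units; beyond the scatter) and repeating the loss seen on the other core. Set side by side, the two steps agree in size:  the same change on two cores in this assay, a 3.2-fold higher number (0.51 log units; beyond the scatter) from compound 1 to compound 2 and a 2.9-fold higher number (0.46 log units; beyond the scatter) from compound 3 to compound 4, 1.1-fold (0.06 log units) apart, within the scatter of two such steps

So in this pair of cores, the change carried over with its cost intact, and swapping one core for the other made no difference to that cost that these numbers can detect. Within the data shown here, that is still only two cores in one cell assay, so it does not show that the same cost would appear on a third core, and it says nothing about why the new group weakens the inhibitor.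

The new group differs from the old one in several ways at once, including a ring nitrogen and a ring carbonyl with an amide hydrogen, so the compounds shown do not reveal which of these parts carries the cost. They also leave open how a plain phenyl group, a pyridine without the second ring, or a carboxylic acid would behave on a saturated chain carbon bound to an amine nitrogen, on either core.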